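Swapping a sulfonamide for a methyl sulfone

A few compounds are considered here, and "the series" means these few. Any claim that something is new, unique, unknown or untested is made for them only; others in the source may bear on it.

Of the compounds shown here, three have been measured in a functional assay on MDA-MB-231 cells (Homo sapiens) for antiproliferative activity, read by MTT assay, with a stated time of 48 h; on this read-out higher numbers stand for weaker inhibition and lower numbers for stronger inhibition. Compound 1 `COc1ccc2nc(Nc3nc(Nc4ccc(S(C)(=O)=O)cc4)ncc3F)sc2c1` gives 4740 nM in this assay. Among the compounds with values here, compound 3 `COc1ccc2nc(Nc3ccnc(Nc4ccc(S(N)(=O)=O)cc4)n3)sc2c1` gives 6240 nM, one of only two plain numbers, and it sits within the usual scatter of the number for compound 1, so the two cannot be told apart. Compound 2 `CS(=O)(=O)c1ccc(Nc2nccc(Nc3nc4ccc(Cl)cc4s3)n2)cc1` reaches only the limit of this assay, > 50000 nM, a limit and not a number (the limit of > 50000 nM in this assay, at which 1 of the 3 values shown sits).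

Compound 4 `COc1ccc2nc(Nc3ccnc(Nc4ccc(S(C)(=O)=O)cc4)n3)sc2c1` has not yet been measured. It differs from compound 3 in one place: methyl in place of amino on a sulfonyl sulfur, a change that reads, one bond further out, as sulfamoyl to methylsulfonyl. Within the data shown here, no pair of measured compounds differs by exactly this change, so there is no measured step to lean on. Compound 4 shares its methylsulfonyl group with compound 1, whose value 4740 nM lies close to that of compound 3. The expected step from compound 3 to compound 4 is a 1.2-fold lower number from compound 3 to compound 4 (0.10 log units; within the scatter), nothing beyond the scatter in either direction. Compound 4 is therefore estimated at 5000 nM, with a range from 2000 nM to 20000 nM.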

Compound 4, half-maximal inhibitory concentration: 32700 nM
Beside the measured number, compound 4's estimate is 6.5-fold (0.82 log units) below it, and the stated range ends below it.
By their numbers in this assay, from the lowest: compounds 1 and 3 (each within the scatter of the next); then compound 4. At a limit, above all of these: compound 2.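

In this assay, methyl and amino are not interchangeable on a sulfonyl sulfur in this series: a 5.2-fold higher number from compound 3 to compound 4 (0.72 log units; beyond the scatter), which means weaker inhibition. The methylsulfonyl group does not settle the outcome alone, since compounds 1 and 4 both carry it and a 6.9-fold higher number from compound 1 to compound 4 (0.84 log units; beyond the scatter), so hydrogen in place of fluoro on an aromatic carbon also weakens inhibition. Compound 2 gives > 50000 nM, a limit and not a number, so an at least 1.5-fold lower number from compound 2 to compound 4 (0.18 log units; that floor lies within the scatter) offers only a floor, and the effect of methoxy in place of chloro on an aromatic carbon cannot be sized.

Nothing given here explains either of the two larger steps. As far as these compounds go, whether fluoro would matter alongside the sulfamoyl group, and how an ethyl or a dimethylamino group on the sulfonyl sulfur would fare, remains open.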